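Removing a Pyridine Methyl in Two Thiosemicarbazide Series

A few compounds are considered here, and "the series" means these few. Any claim that something is new, unique, unknown or untested is made for them only; others in the source may bear on it.

Of the compounds shown here, three have been measured in a functional assay on A-375 cells (Homo sapiens) for cytotoxicity, read by MTT assay, with a stated time of 72 h, tested at 10 uM; a higher number here means more inhibition of growth at the concentration tested, a lower number less inhibition of growth. Compound 1 `N/C(=N\NC(=S)N1CCOCC1)c1ccccn1` gives 18.3%, while compound 2 `Cc1ccnc(/C(N)=N/NC(=S)N2CCOCC2)c1` gives 86%. Compound 2 differs from compound 1 by hydrogen in place of methyl on an aromatic carbon, and the step of a number 67.7 percentage points lower from compound 2 to compound 1 (beyond the scatter). Compound 3 `Cc1cccc(/C(N)=N/NC(=S)N2CCCC2)n1` gives 55.9%; how its core differs from that of compound 2 is not broken down here. Compound 4 `N/C(=N\NC(=S)N1CCCC1)c1ccccn1` has not yet been measured; it differs from compound 3 by hydrogen in place of methyl on an aromatic carbon. This is the same kind of change as from compound 2 to compound 1, but the place differs: in compound 1 the hydrogen sits opposite the ring nitrogen, in compound 4 next to it. Because a number 67.7 percentage points lower from compound 2 to compound 1 (beyond the scatter) was large, compound 4 is expected to fall well below compound 3, with an estimated step of a number 35.9 percentage points lower from compound 3 to compound 4 (beyond the scatter). For compound 4 the estimate in this assay is 20%, between 5% and 50%.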

Compound 4, percent growth inhibition at one concentration: 83.9%
Beside the measured number, compound 4's estimate is 63.9 percentage points below it; measured number above the stated range.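

In this assay the change of methyl to hydrogen on an aromatic carbon did not carry over from one core to the other: the same change on two cores in this assay, a number 67.7 percentage points lower (beyond the scatter) from compound 2 to compound 1 and a number 28 percentage points higher (beyond the scatter) from compound 3 to compound 4, 95.7 percentage points apart, beyond the scatter of two such steps. With hydrogen at that place on both cores, pyrrolidin-1-yl in place of morpholin-4-yl on a thiocarbonyl carbon gives a number 65.6 percentage points higher from compound 1 to compound 4 (beyond the scatter), and the step of a number 28 percentage points higher from compound 3 to compound 4 (beyond the scatter) starts from a methyl next to the ring nitrogen. The two methyl steps differ both in the place of the methyl and in the group on the thiocarbonyl carbon, so these compounds do not show which difference reverses the direction.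

As far as these compounds go, it remains open how each core responds when the methyl sits at the same place on both. Also open, from the compounds shown here alone, is how a piperidin-1-yl group on the thiocarbonyl carbon, or an ethyl or methoxy group in place of the methyl, would read.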